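One Fluoro Added to Compound 2

The compounds below may be only part of what the source reports. "The series", "measured", "known", "first", "only" and "open" are said of these compounds alone.

Of the compounds shown here, two with related structures have so far been tested in an ADME assay on HepG2 cells (Homo sapiens) for cytotoxicity, read by MTT assay, with a stated time of 48 h; a lower number here means a stronger inhibitor, a higher number a weaker inhibitor. Compound 1 (`CN1CCCN(S(=O)(=O)c2ccc(-c3ccc4ncnc(Nc5ccc(OCc6cccc(F)c6)c(Cl)c5)c4c3)cc2)CC1`) gives 1810 nM, a true number. Compound 2 (`O=S(=O)(c1ccc(-c2ccc3ncnc(Nc4ccc(OCc5ccccc5)c(Cl)c4)c3c2)cc1)N1CCOCC1`) reads > 15000 nM, which is a limit of the assay and not a number. Compound 2 therefore stands at the limit of > 15000 nM in this assay, at which 1 of the 2 values shown sits.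

Compound 3 (`O=S(=O)(c1ccc(-c2ccc3ncnc(Nc4ccc(OCc5ccccc5F)c(Cl)c4)c3c2)cc1)N1CCOCC1`) is compound 2 with fluoro in place of hydrogen on an aromatic carbon, which turns benzyloxy into (2-fluorobenzyl)oxy: fluoro in place of hydrogen on an aromatic carbon. Within the data shown here, no measured pair of compounds here shows what this swap does in this assay. For a change of a single fluoro, the expectation is no step beyond the usual scatter, and compound 3 may well be reported only as a limit too. The range is kept wide on the low side, since compound 1 at 1810 nM shows that a related compound can give a much lower reading. The expected change is a step that the limit leaves unreadable from compound 2 to compound 3. Compound 3 is estimated at 20000 nM, with an expected range of 9000 nM to 45000 nM.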

Compound 3, half-maximal inhibitory concentration: > 15000 nM
Compound 3 ended at the assay's limit (the forecaster's own chance of this, stated with the estimate: 70%); the middle value is on the limit's open side.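

Compound 2 and compound 3 both give a limit of the assay rather than a true number, so no step between them can be read in this assay: the limit of > 15000 nM in this assay, at which 2 of the 3 values shown sit.

The compounds shown leave open whether putting (2-fluorobenzyl)oxy in place of benzyloxy changes the reading at all.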